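This account rests on a few compounds, and the source may have more. Where it says the series, first, only, none or still open, it means among the compounds named here.

Among the compounds with values here, compound 2 `CCN(CC)c1ccc2cc(C(=O)NN)c(=O)oc2c1` gives 3360 nM in a functional assay on HCT-116 cells (Homo sapiens) for cytotoxicity, read by MTT assay, with a stated time of 72 h (on this read-out higher numbers stand for weaker inhibition and lower numbers for stronger inhibition), the only number among the two values shown. Compound 1 `CCN(CC)c1ccc2cc(C(=O)NC3CC3)c(=O)oc2c1` gives > 100000 nM there, a limit rather than a number. Within the data shown here, the one measured step, an at least 29-fold lower number from compound 1 to compound 2 (1.47 log units; beyond the scatter), changes the group on the amide-type nitrogen and leaves the aromatic ring untouched. Compound 3 `CCCOc1ccc2cc(C(=O)NN)c(=O)oc2c1` differs from compound 2 on that ring instead: propoxy in place of diethylamino on an aromatic carbon. Among the measured compounds shown here, no measured step changes this part of the shared core, and the amino group on the amide-type nitrogen of compound 2 is kept in compound 3, so the change offers no measured precedent either way. The step from compound 2 to compound 3 is expected to be small, a 1.8-fold higher number from compound 2 to compound 3 (0.25 log units; within the scatter), within or close to the scatter. Compound 3 is therefore estimated at 6000 nM, with a range from 1500 nM to 25000 nM.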

Compound 3, half-maximal inhibitory concentration: 69800 nM
For compound 3 the middle estimate is 12-fold (1.07 log units) below the measured one, outside the stated range (above it).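

In this assay, this aromatic carbon proves to matter as well: with the amino group on the amide-type nitrogen kept, propoxy in place of diethylamino gives a 21-fold higher number from compound 2 to compound 3 (1.32 log units; beyond the scatter). The amino group on that nitrogen therefore does not secure the lower number of compound 2 alone, even though the leaving and entering groups match in hydrogen-bond donors, hydrogen-bond acceptors, rings and charge. Compound 3 still gives a measured number, and compound 1 alone carries a limit: the limit of > 100000 nM in this assay, at which 1 of the 3 values shown sits.

With only two groups shown on this carbon, it remains open whether the nitrogen of diethylamino or the size and shape of the group drives the step; dimethylamino or butoxy would help separate these. Also open, as far as these compounds go, is how cyclopropyl on the amide-type nitrogen would behave alongside propoxy.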